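The source may report more compounds than this note shows. Statements on the series, on what has been measured and on what is new or still open speak of the compounds shown alone.

Measured in an ADME assay on cells (kidney, Cercopithecidae) for cytotoxicity; a lower number here means a stronger inhibitor, a higher number a weaker inhibitor:
Compound 1 `NC(=O)c1cn(COC(CO)CO)c2ncnc(N)c12`: > 100000 nM, a limit of the assay
Compound 2 `N#Cc1cn(C(CO)OC(CO)CO)c2ncnc(N)c12`: > 100000 nM, a limit of the assay

Compound 2 stands only at a limit, > 100000 nM, and no exact number is known for it. The other measured compound shares that position: the limit of > 100000 nM in this assay, at which 2 of the 2 values shown sit.

Compound 3 `NC(=O)c1cn(C(CO)OC(CO)CO)c2ncnc(N)c12` differs from compound 2 in one place, with carbamoyl in place of cyano on an aromatic carbon. This carbon belongs to a five-membered aromatic ring with 1 nitrogen, part of a fused or bridged system of two rings. It lies two ring bonds from the ring nitrogen and two ring bonds from the ring atom that bears a group of 9 heavy atoms.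

Among the compounds with values here, no measured step is available to size this change. The expectation leans on compound 1, which also carries a carbamoyl group and likewise reports only a limit, > 100000 nM. In this assay, the expected change a number no higher from compound 2 to compound 3 (the limit leaves the size open) is no larger than the scatter, with no direction favoured. For compound 3 the estimate is 100000 nM, with an expected range of 50000 nM to 200000 nM.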

Compound 3, half-maximal inhibitory concentration: > 100000 nM
Compound 3: only a limit was reported (the forecaster's own chance of this, stated with the estimate: 90%); the middle value sits exactly at the limit.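

In this assay compound 3 gives > 100000 nM, a limit of the assay. The steps from compound 2 to compound 3 and from compound 1 to compound 3 therefore cannot be read, and all three compounds share one position: the limit of > 100000 nM in this assay, at which 3 of the 3 values shown sit.

The compounds shown leave open whether carbamoyl in place of cyano, or hydroxymethyl in place of hydrogen, changes the read-out in this assay at all.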